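The source may hold more compounds than are shown below. What is called first, only, known or untested is meant among the compounds shown, and "the series" means these compounds.

Of the compounds shown here, two that share a core have been measured in an assay for inhibition of Dihydrofolate reductase (Homo sapiens); a higher number here means a more potent compound, by a factor of ten per unit of this negative logarithm, a lower number a less potent compound. Compound 1 `Nc1nc(O)c2c(Cl)cccc2n1` gives 4.66 in this assay. Compound 2 `Nc1nc(N)c2c(Cl)c(Br)ccc2n1` gives 7 in this assay. Compound 2 thus stands highest of the two numbers, and its nearest neighbour, compound 1, lies lower by a margin well beyond the scatter of repeated measurements. For the measured compounds named here, these two differ in more than one place, so no single step between them can be read off.

The next compound, compound 3 `Nc1nc(N)c2c(Cl)cccc2n1`, has not yet been measured in this assay. It derives from compound 2 by one change: hydrogen in place of bromo on an aromatic carbon. The bromo group leaves an aromatic carbon of the six-membered ring of carbon only, ortho to the chloro group, and a hydrogen takes its place. Going by the values given here, no measured pair shows this change, so its size is uncertain. Since compound 2 gives 7 in this assay, the loss of one heavy atom is expected to cost some potency. The step from compound 2 to compound 3 is expected to be a moderate downward one, a number 0.70 log units lower from compound 2 to compound 3 (beyond the scatter), probably beyond the scatter. Compound 3 is therefore estimated at 6.3, with a range from 5.6 to 7.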

Compound 3, logarithm of the reciprocal of the active concentration, log(1/C): 6.25
The estimate for compound 3 lay 0.05 log units above the measured number, and the stated range covers the measured number.
By their numbers in this assay, from the lowest: compound 1; then compound 3; then compound 2.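

In this assay, replacing the bromo group on the aromatic carbon ortho to a chloro group with hydrogen gives a number 0.75 log units lower from compound 2 to compound 3 (beyond the scatter) and so shows that what sits at this position of the shared core affects the number. Compound 3 also links compound 1 and compound 2, which differ in more than one place, through two single changes, and the second change is the larger: amino in place of hydroxy on an aromatic carbon gives a number 1.59 log units higher from compound 1 to compound 3 (beyond the scatter) and now stands as the biggest single step seen in this small set. Nothing measured here offers a reason for either step.

At the bromo position, only bromo and hydrogen can be compared so far, which leaves open where fluoro, methyl, methoxy or a longer chain would fall, and whether the trend depends on the halogen at all. Going by these compounds, the swap of amino for hydroxy has been read only with hydrogen at that position, so its size with bromo present remains unknown, as does the outcome of replacing the amino group with a methylamino group.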